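The compounds below may be only part of what the source reports. "The series", "measured", "known", "first", "only" and "open" are said of these compounds alone.

Of the compounds shown here, two with a shared core have been tested in a functional assay on MCF7 cells (Homo sapiens) for cytotoxicity, read by neutral red uptake, with a stated time of 3 days; a lower number here means a stronger inhibitor, a higher number a weaker inhibitor. Compound 1 `CCc1c(F)c(N)c2c(=O)cc(-c3ccc(N)c(F)c3)oc2c1F` gives 130 nM. Compound 2 `CCCCCCCCCC(=O)OCc1c(F)c(N)c2c(=O)cc(-c3ccc(N)c(F)c3)oc2c1F`, which carries a nonylcarbonyl on an oxygen on a saturated carbon attached to the core, gives 100 nM. On these two numbers compound 2 stands level with compound 1: the gap between them lies within the usual scatter of repeated measurements, so the two cannot be told apart by this assay.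

Compound 3 `CCCOCc1c(F)c(N)c2c(=O)cc(-c3ccc(N)c(F)c3)oc2c1F` is the next compound, not yet measured. It differs from compound 2 in one place: propyl in place of nonylcarbonyl on an oxygen on a saturated carbon. For the measured compounds named here, no measured pair shows a step of this kind, so its size has to be judged from what is at hand. A small group at this position and a long nonylcarbonyl give near-identical numbers, because compound 1 gives 130 nM while compound 2 gives 100 nM; a propyl of intermediate size is therefore expected to leave the number essentially unchanged. The expected step is a 1.2-fold higher number from compound 2 to compound 3 (0.08 log units; within the scatter), none beyond the scatter. Compound 3 is thus estimated at 120 nM, with a range from 50 nM to 300 nM.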

Compound 3, half-maximal inhibitory concentration: 1200 nM
The estimate for compound 3 lay 10-fold (1.00 log units) below the measured number; the whole stated range lies below it.
By their numbers in this assay, from the lowest: compounds 2 and 1 (each within the scatter of the next); then compound 3.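

In this assay this position proves far from indifferent to what it carries: propyl in place of nonylcarbonyl on an oxygen on a saturated carbon brings a 12-fold higher number from compound 2 to compound 3 (1.08 log units; beyond the scatter) and propoxy in place of methyl on a saturated chain carbon bound to an aromatic carbon brings a 9.2-fold higher number from compound 1 to compound 3 (0.97 log units; beyond the scatter) as well. Compound 1 and compound 2 stood level despite their very different groups, which made the position look tolerant, and compound 3 goes against that picture. The number therefore does not follow group size in any simple way among these three compounds, since the intermediate propoxy stands apart from both the small methyl and the long ester chain.

Going by these compounds, the step from compound 2 to compound 3 shortens the chain and removes the carbonyl at once, so it remains open which of these changes matters; a propanoyl ester or a nonyl ether on the same oxygen would separate the two. No measurement at hand explains why compound 3 stands apart from the other two compounds.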